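Removing the bromine from the pyridine ring of compound 2

The compounds below may be only part of what the source reports. "The series", "measured", "known", "first", "only" and "open" are said of these compounds alone.

Compound 1 `O=C(NO)c1ccc(/C=C/c2ccnc(-c3cccc(CO)c3)c2)cc1` and compound 2 `O=C(NO)c1ccc(/C=C/c2ccnc(Br)c2)cc1` share a core; in an assay on isolated protein for inhibition of protein deacetylase HDAC6 (Homo sapiens), read by fluorescence, with a stated time of 15 min (on this read-out lower numbers stand for stronger inhibition and higher numbers for weaker inhibition), compound 1 gives 34 nM, and compound 2 gives 320 nM. Compound 2 thus stands at the higher of the two numbers, a 9.4-fold higher number from compound 1 to compound 2 (0.97 log units; beyond the scatter). Compound 3 `O=C(NO)c1ccc(/C=C/c2ccncc2)cc1` differs from compound 2 by hydrogen in place of bromo on an aromatic carbon. Going by the values given here, only one measured step touches this position, the exchange of bromo for 3-(hydroxymethyl)phenyl, and it showed that a large group there gives a lower number than bromo. Dropping bromo for hydrogen goes one step further in the direction of a smaller group, so compound 3 is expected to land near compound 2 or somewhat higher, a step of a 1.6-fold higher number from compound 2 to compound 3 (0.19 log units; within the scatter) that may not exceed the scatter. Compound 3 is expected to give 500 nM, with a range from 150 nM to 1700 nM.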

Compound 3, half-maximal inhibitory concentration: 130 nM
Compound 3: middle estimate off by 3.8-fold (0.59 log units), on the high side, outside the stated range (below it).
By their numbers in this assay, from the lowest: compound 1; then compound 3; then compound 2.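

In this assay, bromo does not sit on a smooth path from the large group to hydrogen. There is a 2.5-fold lower number from compound 2 to compound 3 (0.39 log units; beyond the scatter) when bromo is removed, and the smaller group gives the lower number. With hydrogen as the reference, there is also a 3.8-fold higher number from compound 1 to compound 3 (0.58 log units; beyond the scatter) when 3-(hydroxymethyl)phenyl gives way to hydrogen, which places compound 3 between the other two. Among these three compounds, the number therefore does not rise or fall steadily with the count of heavy atoms in the group, and no measurement here explains the order.

Still open, from the compounds shown here alone, is whether the phenyl ring alone or its hydroxymethyl branch accounts for the low number of compound 1. A methyl group or an amine at this position could also fall on either side of hydrogen.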